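The source may hold more compounds than are shown below. What is called first, only, known or untested is meant among the compounds shown, and "the series" means these compounds.

Compound 1 `Cc1ccc(C(=O)NCc2ccc3cc(C(=O)NO)sc3c2F)s1`: 120 nM
Compound 2 `O=C(NCc1ccc2cc(C(=O)NO)sc2c1F)c1ccc[nH]1`: 300 nM

In a functional assay on HCT-116 cells (Homo sapiens) for antiproliferative activity, read by resazurin assay, with a stated time of 5 days (a lower number here means a stronger inhibitor, a higher number a weaker inhibitor), compound 2 holds the higher of the two numbers, at 300 nM. Compound 3 `COc1ccccc1C(=O)NCc1ccc2cc(C(=O)NO)sc2c1F` puts 2-methoxyphenyl in place of 1H-pyrrol-2-yl on a carbonyl carbon. Going by the values given here, one measured step bears on this place: a 2.5-fold higher number from compound 1 to compound 2 (0.40 log units; beyond the scatter), modest and beyond the scatter. Leaving the 1H-pyrrol-2-yl group behind may therefore recover a modest amount, although no 2-methoxyphenyl comparison exists. The estimated step is a 1.5-fold lower number from compound 2 to compound 3 (0.18 log units; within the scatter), small and towards a lower number. For compound 3 the expected value is 200 nM, with an estimated range of 70 nM to 550 nM.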

Compound 3, half-maximal inhibitory concentration: 1200 nM
Compound 3: the middle estimate sits 6.0-fold (0.78 log units) below what was measured, outside the stated range (above it).
By their numbers in this assay, from the lowest: compound 1; then compound 2; then compound 3.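

Replacing the 1H-pyrrol-2-yl group with 2-methoxyphenyl on this carbonyl carbon in this assay does not recover activity; it gives the largest change yet from compound 2 (a 4.0-fold higher number from compound 2 to compound 3 (0.60 log units; beyond the scatter)). Measured against the 5-methylthiophen-2-yl group, the change is wider still (a 10-fold higher number from compound 1 to compound 3 (1.00 log units; beyond the scatter)). This position therefore tolerates these groups unequally, and 2-methoxyphenyl ranks last of the three.

Nothing available explains this order. As far as these compounds go, whether a plain phenyl group or a pyridine ring would follow compound 3 or compound 1 remains open.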